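Undefined stereocentre and the solubility of compound 4

The compounds below may be only part of what the source reports. "The series", "measured", "known", "first", "only" and "open" are said of these compounds alone.

Compound 1 `N#Cc1ccc(-c2cnc(N)c(-c3ccc(N)nc3)n2)cc1` gives in a physicochemical assay for solubility, read by HPLC, using the shake flask method, in phosphate buffer, with a stated time of 2 h, at pH 6.5 (on this read-out lower numbers stand for lower solubility and higher numbers for higher solubility), only a limit, < 5000 nM, (the limit of < 5000 nM in this assay, at which 1 of the 3 values shown sits). Compound 2 `CS(=O)(=O)c1ccc(-c2cnc(N)c(-c3ccc(N)nc3)n2)cc1` gives 149000 nM, a change of an at least 29-fold higher number from compound 1 to compound 2 (1.47 log units; beyond the scatter). Compound 3 `Nc1ncc(-c2ccc(C(=O)N3CC[C@H](O)C3)cc2)nc1-c1ccc(C(F)(F)F)cc1` gives 68000 nM, the lowest of the two numbers; compound 2 stands higher, beyond the scatter. Compound 4 `Nc1ncc(-c2ccc(C(=O)N3CCC(O)C3)cc2)nc1-c1ccc(C(F)(F)F)cc1` has not yet been measured. The change is the two compounds have the same atoms and bonds; at least one stereo element is drawn with a configuration in one of them and without one in the other: 1 of 1 stereo elements differ; a stereocentre at a saturated ring carbon is drawn S in compound 3 and without a configuration in compound 4. Within the data shown here, the single measured step, which swaps one group for another, does not bear on this change. Since the two compounds share every atom and bond, no step beyond the scatter is expected, and the expected step from compound 3 to compound 4 is no change at the digits printed from compound 3 to compound 4 (within the scatter). Compound 4 is therefore estimated at 68000 nM, with a range from 34000 nM to 136000 nM.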

Compound 4, solubility: 77000 nM
For compound 4 the middle estimate is 1.1-fold (0.05 log units) below the measured one, within the range that was stated.
By their numbers in this assay, from the lowest: compounds 3, 4 and 2 (each within the scatter of the next, the first and the last beyond it). At a limit, below all of these: compound 1.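

In this assay, leaving the configuration undrawn at the saturated ring carbon gives a 1.1-fold higher number from compound 3 to compound 4 (0.05 log units; within the scatter), so the two compounds read alike. The earlier step swapped one group for another, whereas this is the first to test the drawn configuration alone, and the only structural difference here is: the fact that one of compounds 3 and 4 is drawn with a defined configuration and the other without, at the place where they differ

From the compounds shown here alone, the drawing of compound 4 does not say which forms of that carbon it contains, so how the R form alone would read stays open. Also open, going by these compounds, is how an amine or a carboxylic acid in place of the hydroxyl would read.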